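The compounds below may be only part of what the source reports. "The series", "measured", "known", "first", "only" and "open" are said of these compounds alone.

Measured compounds in a functional assay, with a stated time of 90 s; on this read-out lower numbers stand for stronger inhibition and higher numbers for weaker inhibition:
compound 1 `Cc1nc2c3ccccc3ccc2c2nc3c(ccc4ccccc43)c(-c3cccc4ccccc34)c12` gives 179 ug/mL
compound 2 `Cc1nc2c3ccccc3ccc2c2nc3c(ccc4ccccc43)c(-c3ccc(O)cc3)c12` gives 99 ug/mL

Within the data shown here, compound 2 and compound 1 are the only two measured members so far. Among the measured compounds shown here, the single measured step, a 1.8-fold lower number from compound 1 to compound 2 (0.26 log units; within the scatter), places the two numbers within the scatter of each other, so compound 2 cannot be told apart from compound 1 in this assay; it simply stands as one of two indistinguishable values.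

The next member, compound 3 `Cc1nc2c3ccccc3ccc2c2nc3c(ccc4ccccc43)c(-c3cc(O)nc4ccccc34)c12`, is not yet measured. Its change from compound 2: 2-hydroxyquinolin-4-yl in place of 4-hydroxyphenyl on an aromatic carbon. For the measured compounds named here, only one measured step bears on this position, a 1.8-fold lower number from compound 1 to compound 2 (0.26 log units; within the scatter), in which a group with two fused rings of carbon only gave way to a single ring carrying a hydroxy group without a shift beyond the scatter. Compound 3 keeps the hydroxy group and again carries one six-membered aromatic ring of carbon only together with one six-membered aromatic ring with 1 hetero atom. On that basis no step beyond the scatter is expected for compound 3 in this assay, a 1.1-fold higher number from compound 2 to compound 3 (0.05 log units; within the scatter). The estimate for compound 3 is 110 ug/mL, with a range from 50 ug/mL to 250 ug/mL.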

Compound 3, half-maximal inhibitory concentration: 148 ug/mL
Beside the measured number, compound 3's estimate is 1.3-fold (0.13 log units) below it, and the stated range covers the measured number.
By their numbers in this assay, from the lowest: compounds 2, 3 and 1 (each within the scatter of the next).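

In this assay the position opposite the ring nitrogen has now carried three different aromatic groups, and neither new step separates them: a 1.5-fold higher number from compound 2 to compound 3 (0.17 log units; within the scatter), and a 1.2-fold lower number from compound 1 to compound 3 (0.08 log units; within the scatter). Neither the second fused ring nor the ring nitrogen of 2-hydroxyquinolin-4-yl distinguishes compound 3 from compound 2, which carries 4-hydroxyphenyl, and the same group with its hydroxy also leaves compound 3 indistinguishable from compound 1, which carries naphthalen-1-yl. Nothing available offers an independent measurement that could account for this lack of separation.

From the compounds shown here alone, all three groups at this position are built from six-membered aromatic rings, so it remains open whether a plain phenyl, a methoxyphenyl, an amine, a carboxylic acid or a longer alkyl chain there would give a step beyond the scatter. The methyl group on the shared core stays the same throughout, so the compounds shown say nothing about changes at any other place on the core.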